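Amide nitrogen substituent and cytotoxicity in the series

The compounds below may be only part of what the source reports. "The series", "measured", "known", "first", "only" and "open" are said of these compounds alone.

Three members of the series have been run in an ADME assay on Huh-7 cells (Homo sapiens) for cytotoxicity, read by a luciferase reporter and WST assay, with a stated time of 3 days; on this read-out lower numbers stand for higher toxicity in this test and higher numbers for lower toxicity in this test. Compound 1 `O=C(Nc1ccccc1)c1c(NO)cc(-c2ccc(F)cc2)oc1=O` gives 10300 nM. Compound 2 `O=C(Nc1ccc(Cl)cc1)c1c(NO)cc(-c2ccccc2)oc1=O` reaches only the limit of this assay, reported as > 20000 nM and not as a number. Compound 3 `COc1ccc(-c2cc(NO)c(C(=O)Nc3ccc(C)cc3)c(=O)o2)cc1` likewise stops at the limit, > 20000 nM, again a limit rather than a number. For the measured compounds named here, compound 2 therefore sits at the ceiling of what this assay can resolve, and it shares that position with compound 3, while compound 1 is the single member with a numerical half-maximal cytotoxic concentration. Going by the values given here, no pair of measured compounds differs in one place, so no measured step is available to calibrate against.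

The next compound, compound 4 `O=C(NCCO)c1c(NO)cc(-c2ccccc2)oc1=O`, differs from compound 2 by 2-hydroxyethyl in place of 4-chlorophenyl on an amide-type nitrogen. Because (the limit of > 20000 nM in this assay, at which 2 of the 3 values shown sit), the starting point for this step is unresolved, and only a move toward higher toxicity could show up as a change beyond the scatter. The expected step is a step that the limit leaves unreadable from compound 2 to compound 4, that is, no change beyond the scatter. Compound 4 is estimated to give 25000 nM in this assay, with a range from 10000 nM to 60000 nM, and most likely again only a limit.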

Compound 4, half-maximal cytotoxic concentration: > 20000 nM
Compound 4 gave a limit, no number; the forecaster's own chance of this, stated with the estimate: 75%; the middle value lies beyond the limit too.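

In this assay compound 4 gives > 20000 nM as a limit and not a number. For the compounds shown here, compound 2 also stands at a limit, so no step between compound 2 and compound 4 can be read: the limit of > 20000 nM in this assay, at which 3 of the 4 values shown sit.

Still open, as far as these compounds go, is whether 2-hydroxyethyl in place of 4-chlorophenyl on the amide-type nitrogen changes the half-maximal cytotoxic concentration at all.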